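The compounds below may be only part of what the source reports. "The series", "measured", "known", "first", "only" and "open" are said of these compounds alone.

Compound 1, with the structure `O=C(Nc1n[nH]c2cc(-c3cn([C@@H]4CN[C@H](C(=O)Nc5ccc(Cl)cc5Cl)C4)nn3)ccc12)C1CC1`, and compound 2, with the structure `O=C(Nc1n[nH]c2cc(-c3cn([C@@H]4CN[C@H](C(=O)Nc5ccc(Br)cc5)C4)nn3)ccc12)C1CC1`, share one core and differ only in the group on the amide nitrogen. The change between them is 4-bromophenyl in place of 2,4-dichlorophenyl on an amide-type nitrogen. In a functional assay on K562 cells (Homo sapiens) for inhibition, read by MTT assay, with a stated time of 48 h (on this read-out lower numbers stand for stronger inhibition and higher numbers for weaker inhibition), compound 1 gives 5340 nM, while compound 2 gives 8080 nM, so the change produced a 1.5-fold higher number from compound 1 to compound 2 (0.18 log units; within the scatter), a step that does not rise above the usual scatter.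

Compound 3, with the structure `Nc1nc2ccc(-c3cn([C@@H]4CN[C@H](C(=O)Nc5ccc(Cl)cc5Cl)C4)nn3)nc2s1`, carries the 2,4-dichlorophenyl group of compound 1 but on a different core; how the two cores differ is not broken down here. In this assay compound 3 gives 24500 nM, the highest of the three measured numbers, and its gap to both compound 1 and compound 2 lies beyond the scatter.

Compound 4, with the structure `Nc1nc2ccc(-c3cn([C@@H]4CN[C@H](C(=O)Nc5ccc(Br)cc5)C4)nn3)nc2s1`, has not yet been measured. It stands to compound 3 as compound 2 stands to compound 1: the change is 4-bromophenyl in place of 2,4-dichlorophenyl on an amide-type nitrogen, made at the same place, so it is the same change on a different core. For compound 4 the expected value in this assay is 32000 nM, with a likely range from 14000 nM to 75000 nM. This estimate means a step of a 1.3-fold higher number from compound 3 to compound 4 (0.12 log units; within the scatter), which rests on the earlier step of a 1.5-fold higher number from compound 1 to compound 2 (0.18 log units; within the scatter) being within the scatter, so little movement is expected here either.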

Compound 4, half-maximal inhibitory concentration: 24400 nM
Compound 4: middle estimate off by 1.3-fold (0.12 log units), on the high side, and the stated range covers the measured number.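

In this assay, putting 4-bromophenyl in place of 2,4-dichlorophenyl on the amide-type nitrogen gives a 1.0-fold lower number from compound 3 to compound 4 (0.00 log units; within the scatter). Set beside the same change on the core of compound 1, the two steps do not differ by more than the scatter, so the change behaves alike on both cores: the same change on two cores in this assay, a 1.5-fold higher number (0.18 log units; within the scatter) from compound 1 to compound 2 and a 1.0-fold lower number (0.00 log units; within the scatter) from compound 3 to compound 4, 1.5-fold (0.18 log units) apart, within the scatter of two such steps. This shows only that, for these two groups and these two cores, the swap can be carried across without a readable shift in the number; it rests on one pair per core, so it is no general rule, and since neither step rises above the scatter, it does not show that a change with a large effect on one core would carry over to the other.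

The compounds shown leave open what other groups on that amide nitrogen would do on either core, such as a phenyl ring carrying an amine or a carboxylic acid, or a longer alkyl chain in place of the ring. They also leave open whether such a group, if it gave a step beyond the scatter on one core, would give a matching step on the other, which would be a sterner test of carrying a change across.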